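This account rests on a few compounds, and the source may have more. Where it says the series, first, only, none or still open, it means among the compounds named here.

The measured compounds:
Compound 1 `O=C(COc1cccc2ccccc12)N/N=C/c1ccc(Cl)cc1` — in an ADME assay on MT4 cells (Homo sapiens) for cytotoxicity, read by MTT assay, with a stated time of 4 days (on this read-out lower numbers stand for higher toxicity in this test and higher numbers for lower toxicity in this test), compound 1 gives 87.6 ug/mL.
Compound 2 `O=C(COc1cccc2ccccc12)N/N=C/c1cccc(O)c1` — in this assay compound 2 gives 32.6 ug/mL.

Among these two numbers compound 2 stands lowest, with compound 1 the only other point of comparison. Within the data shown here, the one measured step, a 2.7-fold lower number from compound 1 to compound 2 (0.43 log units; beyond the scatter), is modest yet beyond the scatter. Compound 3 `O=C(COc1cccc2ccccc12)N/N=C/c1cccc([N+](=O)[O-])c1` has not been measured. It differs from compound 2 in a single place: nitro in place of hydroxy on an aromatic carbon. Among the measured compounds shown here, no measured step exchanges hydroxy for nitro, so the only guidance is indirect: the step of a 2.7-fold lower number from compound 1 to compound 2 (0.43 log units; beyond the scatter) concerns a different exchange on the same aromatic ring and shows that such an exchange moved the number only modestly. On that basis the present change is expected to shift this assay by a small amount, in a direction that cannot be fixed from the data. The step of a 1.5-fold higher number from compound 2 to compound 3 (0.19 log units; within the scatter) is therefore estimated to be small, most likely within or near the scatter. Compound 3 is expected to give about 50 ug/mL, with a range from 20 ug/mL to 120 ug/mL.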

Compound 3, half-maximal cytotoxic concentration: 12.1 ug/mL
Beside the measured number, compound 3's estimate is 4.1-fold (0.62 log units) above it, outside the stated range (below it).
By their numbers in this assay, from the lowest: compound 3; then compound 2; then compound 1.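

The exchange of hydroxy for nitro on an aromatic carbon, meta to a large group, gives a 2.7-fold lower number from compound 2 to compound 3 (0.43 log units; beyond the scatter) in this assay. The earlier step changed the group and its place on the ring together, so it could not show what the group alone does; this step keeps the place fixed and shows that changing the group alone moves the number beyond the scatter, by a step of modest size. The compounds shown offer no measurement that accounts for this fall, and the loss of the hydrogen-bond donor cannot be separated from the other differences between the two groups.

With only hydroxy and nitro compared at this place, two groups give a direction for one exchange but no order that could be extended to other groups, and an amine or a carboxylic acid on the same aromatic carbon would show whether the number keeps falling or turns back. From the compounds shown here alone, it also remains open whether a methoxy group there would stay close to hydroxy or move towards nitro.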